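Swapping a Methoxy Group for an Isoxazole Ring

The source may report more compounds than this note shows. Statements on the series, on what has been measured and on what is new or still open speak of the compounds shown alone.

Compound 1 `CON(Cc1cccs1)C(=O)COc1ccc(C)cc1` is the reference here. In an assay on HEK293 cells for agonist activity at transient receptor potential cation channel subfamily M member 8 (Homo sapiens), read by fluorescence and calcium flux, with a stated time of 15 min (on this read-out lower numbers stand for an effect already at smaller amounts and higher numbers for an effect only at larger amounts of compound), compound 1 gives 10 nM, the lowest of the two numbers measured, while compound 2 `CCN(Cc1ccc(C)s1)C(=O)COc1ccc(C)cc1` gives 178 nM, a gap beyond the usual scatter. Compound 3 `Cc1ccc(OCC(=O)N(Cc2cccs2)c2ccon2)cc1` has not been measured yet; it differs from compound 1 as follows: 1,2-oxazol-3-yl in place of methoxy on an amide-type nitrogen. For the measured compounds named here, no measured pair shows the effect of this change, so its size is uncertain; a moderate loss of potency seems most likely, though a result within the scatter cannot be ruled out. Compound 3 is expected to give 40 nM, within 8 nM to 250 nM, an estimated step of a 4.0-fold higher number from compound 1 to compound 3 (0.60 log units; beyond the scatter).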

Compound 3, half-maximal effective concentration: 2 nM
Beside the measured number, compound 3's estimate is 20-fold (1.30 log units) above it, outside the stated range (below it).
By their numbers in this assay, from the lowest: compound 3; then compound 1; then compound 2.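

On an amide-type nitrogen, methoxy can give way to the larger 1,2-oxazol-3-yl ring with a gain rather than a loss: in this assay the change gives a 5.0-fold lower number from compound 1 to compound 3 (0.70 log units; beyond the scatter). For the compounds shown here, this position therefore accepts a five-membered aromatic ring with 2 hetero atoms, which the earlier compounds could not show. Nothing available here explains the gain.

Still open, from the compounds shown here alone, is whether this particular ring is needed, or whether a phenyl ring or a pyridine ring on the same nitrogen would serve as well.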